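Ether-acid side chain: removing the chain methyl

A few compounds are considered here, and "the series" means these few. Any claim that something is new, unique, unknown or untested is made for them only; others in the source may bear on it.

Measured so far in a functional assay on HL-60 cells (Homo sapiens) for antiproliferative activity, with a stated time of 72 h; a higher number here means a weaker inhibitor of growth, a lower number a stronger inhibitor of growth:
compound 1 `C=C(CCCC)C(=O)c1ccc(OCC(=O)OC)c(C)c1C` gives 8600 nM.
compound 2 `C=C(CCCC)C(=O)c1ccc(OC(C)C(=O)OC)c(C)c1C` gives 5200 nM.
compound 3 `C=C(C)C(=O)c1ccc(OC(C)C(=O)O)cc1Cl` gives > 60000 nM, which is a limit of the assay and not a number.

Compounds 1 and 2 share one core and differ by hydrogen in place of methyl on a saturated chain carbon bound to a carbonyl carbon and an oxygen on an aromatic ring. This step reads a 1.7-fold higher number from compound 2 to compound 1 (0.22 log units; within the scatter). Compound 3 has another core, and the difference between the two cores is not broken down here. Compound 3 sits at the limit of > 60000 nM in this assay, at which 1 of the 3 values shown sits.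

Compound 4 `C=C(C)C(=O)c1ccc(OCC(=O)O)cc1Cl` is not yet measured. Among the measured compounds shown here, from compound 3 it differs by hydrogen in place of methyl on a saturated chain carbon bound to a carbonyl carbon and an oxygen on an aromatic ring, the same change as the one between compound 2 and compound 1, at the same place. For compound 4 the step in this assay is expected to be a step that the limit leaves unreadable from compound 3 to compound 4, small, because a 1.7-fold higher number from compound 2 to compound 1 (0.22 log units; within the scatter). Compound 3 gives only the limit > 60000 nM. Compound 4 is therefore expected to stay near that limit, at an estimated 80000 nM with a range from 30000 nM to 250000 nM, and most likely to return a limit again rather than a number.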

Compound 4, concentration for 50% growth inhibition: > 60000 nM
Compound 4 gave a limit, no number (the forecaster's own chance of this, stated with the estimate: 75%); the middle value lies beyond the limit too.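

In this assay, compound 3 and compound 4 each return a limit and not a number, so no step can be read between them: the limit of > 60000 nM in this assay, at which 2 of the 4 values shown sit.

The compounds shown leave open whether the change from 1-carboxyethoxy to carboxymethoxy alters growth inhibition on the core of compound 3 at all.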